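A few compounds are considered here, and "the series" means these few. Any claim that something is new, unique, unknown or untested is made for them only; others in the source may bear on it.

Working notes on the series. Compound 1 `CCCOCC(=O)Nc1cc2nc(C3CCCCC3)[nH]c2cc1N(C)C` carries a propoxymethyl on the carbonyl carbon of the amide. In an ADME assay on Vero cells (Chlorocebus sabaeus) for cytotoxicity, read by resazurin assay, with a stated time of 3 days (a higher number here means a weaker inhibitor, a lower number a stronger inhibitor), compound 1 reaches only a limit, < 50 ug/mL. Compound 2 `CCc1ccc(C(=O)Nc2cc3nc(C4CCCCC4)[nH]c3cc2N(C)C)cc1` has a 4-ethylphenyl at that carbonyl carbon. In this assay compound 2 gives a limit, > 100 ug/mL. Compound 3 `CN(C)c1cc2[nH]c(C3CCCCC3)nc2cc1NC(=O)c1ccc(F)cc1F` carries a 2,4-difluorophenyl at the carbonyl carbon. In this assay compound 3 likewise gives a limit, > 100 ug/mL. Compound 3 thus stands at the upper limit with no number, sharing it with one other compound (the limit of > 100 ug/mL in this assay, at which 2 of the 3 values shown sit), while one compound sits at the lower limit (the limit of < 50 ug/mL in this assay, at which 1 of the 3 values shown sits). The steps of an at least 2.0-fold higher number from compound 1 to compound 2 (0.30 log units; that floor lies within the scatter) and an at least 2.0-fold higher number from compound 1 to compound 3 (0.30 log units; that floor lies within the scatter) are read only as floors, and a step that the two limits leave unreadable from compound 2 to compound 3 is not readable at all.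

Compound 4 `Cc1ccc(C(=O)Nc2cc3nc(C4CCCCC4)[nH]c3cc2N(C)C)cc1` differs from compound 3 by 4-methylphenyl in place of 2,4-difluorophenyl on a carbonyl carbon. Within the data shown here, the change stays among the aryl amides, both measured members of which sit at the same upper limit, and no measured step between aryl amides is readable. Compound 4 is therefore expected at 150 ug/mL, between 80 ug/mL and 300 ug/mL. The expected step is a step that the limit leaves unreadable from compound 3 to compound 4, nothing beyond the scatter, most likely again reported only as a limit.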

Compound 4, half-maximal inhibitory concentration: > 100 ug/mL
Compound 4 was reported as a limit; the forecaster's own chance of this, stated with the estimate: 75%; the middle value does not contradict the limit.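

On the carbonyl carbon, a third aryl group now stands at the upper limit of this assay, and this one, 4-methylphenyl, has no fluorine: the limit of > 100 ug/mL in this assay, at which 3 of the 4 values shown sit. Both steps among the aryl amides that end at compound 4 cannot be read, so neither the exchange of 2,4-difluorophenyl for 4-methylphenyl nor the shortening of 4-ethylphenyl to 4-methylphenyl has a size. The contrast with the propoxymethyl amide gains one more floor, an at least 2.0-fold higher number from compound 1 to compound 4 (0.30 log units; that floor lies within the scatter), and it matches the floors already held by compound 2 and compound 3.

The compounds shown leave open where any aryl amide truly falls and whether the gap to compound 1 exceeds the scatter. Also open, as far as these compounds go, is whether an amine or a carboxylic acid on the phenyl ring would bring a value inside the limit.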